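This account rests on a few compounds, and the source may have more. Where it says the series, first, only, none or still open, it means among the compounds named here.

Measured so far:
compound 1, `Cc1cc(C)cc(NC(=O)CN2CCC(c3cccc[n+]3[O-])CC2)c1`, 52 nM;
compound 2, `O=C(NCN1CCC(c2cccc[n+]2[O-])CC1)c1cc(Cl)cc(Cl)c1`, 45 nM;
compound 3, `Cc1cccc(NC(=O)CN2CCC(c3cccc(F)c3)CC2)c1`, 512 nM.

In a functional assay on HEK293 cells for agonist activity at D(4) dopamine receptor (Homo sapiens), read by FLIPR (a higher number here means that more compound is needed for the effect, a lower number that less compound is needed), compound 1 has the second highest of the three numbers. Compound 2 sits within the scatter of compound 1. Compound 3 gives the highest number, beyond the scatter of the other two.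

Compound 4, `Cc1cccc(C)c1NC(=O)CN1CCC(c2cccc[n+]2[O-])CC1`, is not yet measured. It keeps the core of compound 1 with one change: 2,6-dimethylphenyl in place of 3,5-dimethylphenyl on an amide-type nitrogen. Within the data shown here, no step between measured compounds informs this change, so the direction rests on the change alone. The step of a 2.3-fold higher number from compound 1 to compound 4 (0.36 log units; beyond the scatter) in this assay is expected to be a modest rise, near the edge of the scatter. Compound 4 is estimated at 120 nM, between 30 nM and 500 nM.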

Compound 4, half-maximal effective concentration: 346 nM
Compound 4: middle estimate off by 2.9-fold (0.46 log units), on the low side; the range from low to high includes it.
By their numbers in this assay, from the lowest: compounds 2 and 1 (each within the scatter of the next); then compounds 4 and 3 (each within the scatter of the next).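

In this assay, exchanging 3,5-dimethylphenyl for 2,6-dimethylphenyl on the amide-type nitrogen gives a 6.7-fold higher number from compound 1 to compound 4 (0.82 log units; beyond the scatter). Among these compounds, with the atom counts unchanged, the placement of the two methyl groups on this phenyl ring alone shifts the number, which the earlier compounds could not show. Nothing at hand bears on why the number rises.

From the compounds shown here alone, whether ethyl or methoxy groups in place of the methyl groups would show the same dependence on placement stays open. Also open, going by these compounds, is whether this change would carry over to other cores.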